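A Second Hydroxy Group on the Pendant Ring

The source may hold more compounds than are shown below. What is called first, only, known or untested is meant among the compounds shown, and "the series" means these compounds.

In a functional assay on A2780 cells (Homo sapiens) for inhibition, read by trypan blue exclusion, with a stated time of 72 h (a lower number here means a stronger inhibitor of growth, a higher number a weaker inhibitor of growth), compound 2 `CCCn1c(-c2ccc(O)cc2)c(C)c2cc(O)ccc21` gives 2300 nM, the lowest of the two numbers seen so far, while compound 1 `CCCn1c(-c2ccc(O)cc2)c(C)c2ccccc21` gives 9000 nM. Among the measured compounds shown here, the only measured step, a 3.9-fold lower number from compound 1 to compound 2 (0.59 log units; beyond the scatter), came from a hydroxy in place of hydrogen on an aromatic carbon. Compound 3 `CCCn1c(-c2ccc(O)c(O)c2)c(C)c2cc(O)ccc21` carries hydroxy in place of hydrogen on an aromatic carbon, ortho to a hydroxy group and meta to a large group. Because a 3.9-fold lower number from compound 1 to compound 2 (0.59 log units; beyond the scatter) was only modest, a step of similar or smaller size in the same direction is expected, a 1.5-fold lower number from compound 2 to compound 3 (0.19 log units; within the scatter). Compound 3 is therefore estimated at 1500 nM, between 500 nM and 5000 nM.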

Compound 3, concentration for 50% growth inhibition: 8400 nM
For compound 3 the middle estimate is 5.6-fold (0.75 log units) below the measured one, outside the stated range (above it).
By their numbers in this assay, from the lowest: compound 2; then compounds 3 and 1 (each within the scatter of the next).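

In this assay the same exchange that lowered the number on the other ring ran the opposite way here: a hydroxy ortho to a hydroxy group and meta to a large group gave a 3.7-fold higher number from compound 2 to compound 3 (0.56 log units; beyond the scatter) on the pendant ring. Across the two listed steps, the direction of this change therefore depends on where the hydroxy enters. Nothing measured here accounts for this reversal. The compounds shown leave open whether a methoxy group or an amine in this same place would raise the number as the hydroxy does.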